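Sulfonyl in place of dienoyl amide on the shared core

The source may report more compounds than this note shows. Statements on the series, on what has been measured and on what is new or still open speak of the compounds shown alone.

Three amides of the shared core have been measured in a functional assay on SiHa cells (Homo sapiens) for cytotoxicity, read by MTT assay, with a stated time of 48 h; on this read-out higher numbers stand for weaker inhibition and lower numbers for stronger inhibition. Compound 1 `CCCCCCCCCCCCCCNC(=O)[C@@H](NC(=O)c1ccccc1)[C@@H](C)O` reaches only a limit, > 200000 nM. Compound 2 `CCCCCCCCCCCCCCNC(=O)[C@@H](NC(=O)c1ccco1)[C@@H](C)O` gives 127000 nM. Compound 3 `C/C=C/C=C/C(=O)N[C@H](C(=O)NCCCCCCCCCCCCCC)[C@@H](C)O` likewise stops at a limit, > 200000 nM. Compound 3 therefore stands with compound 1 at the limit of > 200000 nM in this assay, at which 2 of the 3 values shown sit, where the step from compound 1 to compound 3 is a step that the two limits leave unreadable from compound 1 to compound 3; against compound 2 it shows an at least 1.5-fold higher number from compound 2 to compound 3 (0.19 log units; that floor lies within the scatter), and compound 1 against compound 2 shows an at least 1.5-fold lower number from compound 1 to compound 2 (0.19 log units; that floor lies within the scatter). Compound 4 `CCCCCCCCCCCCCCNC(=O)[C@@H](NS(=O)(=O)c1ccc(C)cc1)[C@@H](C)O` differs from compound 3 by (4-methylphenyl)sulfonyl in place of (penta-1,3-dien-1-yl)carbonyl on an amine nitrogen. Among the compounds with values here, no measured step exchanges a carbonyl group for a sulfonyl group, so none bears directly on this change; the readable steps among phenyl, furan-2-yl and penta-1,3-dien-1-yl on the carbonyl carbon all sit at floors within the scatter. For compound 4 the expected change is small, an at least 1.1-fold lower number from compound 3 to compound 4 (0.04 log units; that floor lies within the scatter), and a limit rather than a number is again likely. Compound 4 is estimated at 180000 nM, within 60000 nM to 600000 nM.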

Compound 4, half-maximal inhibitory concentration: 19200 nM
Compound 4: the middle estimate sits 9.4-fold (0.97 log units) above what was measured, outside the stated range (below it).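

In this assay, within the data shown here, the exchange on the amine nitrogen gives the first steps beyond the scatter, and compound 4 stands as the strongest of the four: an at least 10-fold lower number from compound 3 to compound 4 (1.01 log units; beyond the scatter) and an at least 10-fold lower number from compound 1 to compound 4 (1.01 log units; beyond the scatter). Only a 6.6-fold lower number from compound 2 to compound 4 (0.82 log units; beyond the scatter) has a number at both ends, so it alone gives a full size, while the other two are floors resting on a limit: the limit of > 200000 nM in this assay, at which 2 of the 4 values shown sit. At this position, then, the (4-methylphenyl)sulfonyl group separates from all three carbonyl groups shown, whose own readable steps stay at floors within the scatter.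

Going by these compounds, the sulfonyl and the 4-methylphenyl ring enter together, so which of them carries the step stays open. A 4-methylbenzoyl or a methylsulfonyl group on the same nitrogen would separate the two.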